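Changing the side chain on a shared core

The source may report more compounds than this note shows. Statements on the series, on what has been measured and on what is new or still open speak of the compounds shown alone.

Compound 1 `CCCN1CCN(CCCCn2c3c(c4ccccc42)C(=O)c2c[n+]([O-])c4ccccc4c2C3=O)CC1` gives 2980 nM
Compound 2 `CN1CCN(CCCCCn2c3c(c4ccccc42)C(=O)c2c[n+]([O-])c4ccccc4c2C3=O)CC1` gives 2270 nM

In a functional assay on MDA-MB-231 cells (Homo sapiens) for cytotoxicity, read by MTT assay, with a stated time of 72 h (a higher number here means a weaker inhibitor, a lower number a stronger inhibitor), compound 2 sits within the usual scatter of compound 1, so the two stand level. Compound 3 `O=C1c2c[n+]([O-])c3ccccc3c2C(=O)c2c1c1ccccc1n2CCCN1CCC(O)CC1` differs from compound 2 in its side chain (4-hydroxypiperidin-1-yl in place of 2-(4-methylpiperazin-1-yl)ethyl on a saturated chain carbon, three bonds along the chain from an aromatic nitrogen), with 4-hydroxypiperidin-1-yl in place of 2-(4-methylpiperazin-1-yl)ethyl. Among the compounds with values here, the only measured step, leading to compound 2 (a 1.3-fold lower number from compound 1 to compound 2 (0.12 log units; within the scatter)), changed a different group, so it guides only loosely and no step beyond the scatter is expected. The estimated value for compound 3 is 2500 nM (range 800 nM to 7000 nM) in this measurement. The expected step (a 1.1-fold higher number from compound 2 to compound 3 (0.04 log units; within the scatter)) has no firm direction.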

Compound 3, half-maximal inhibitory concentration: 280 nM
The estimate for compound 3 lay 8.9-fold (0.95 log units) above the measured number; measured number below the stated range.
By their numbers in this assay, from the lowest: compound 3; then compounds 2 and 1 (each within the scatter of the next).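

The side chain on the aromatic nitrogen turns out to matter, which the level pair of compound 1 and compound 2 gave no sign of: the change to 3-(4-hydroxypiperidin-1-yl)propyl brings an 8.1-fold lower number from compound 2 to compound 3 (0.91 log units; beyond the scatter) and, against the other piperazine, an 11-fold lower number from compound 1 to compound 3 (1.03 log units; beyond the scatter) as well. Nothing available explains this gain.

The change shortens the chain and replaces the ring together, and the compounds shown do not separate the two. A 5-(4-hydroxypiperidin-1-yl)pentyl chain would test the ring alone, and a plain piperidine would test the hydroxyl.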